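The compounds below may be only part of what the source reports. "The series", "measured", "known", "first", "only" and "open" are said of these compounds alone.

Compound 1, `O=C(Nc1ccc(F)cc1)N[C@H]1CC[C@H](Oc2ccc(F)cc2)CC1`, gives 20000 nM in a functional assay on CRL2813 cells (Homo sapiens) for cytotoxicity, read by sulforhodamine B assay, with a stated time of 5 days; on this read-out lower numbers stand for stronger inhibition and higher numbers for weaker inhibition.
Compound 2, `Cc1cccc(NC(=O)N[C@H]2CC[C@H](Oc3ccc(F)cc3)CC2)c1`, gives 14400 nM in this assay.
Compound 3, `O=C(Nc1ccccc1Cl)N[C@H]1CC[C@H](Oc2ccc(F)cc2)CC1`, gives 9100 nM in this assay.

Compound 3 has the lowest of the three numbers in this assay: the step of a 1.6-fold lower number from compound 2 to compound 3 (0.20 log units; within the scatter) stays within the scatter, while a 2.2-fold lower number from compound 1 to compound 3 (0.34 log units; beyond the scatter) is modest but beyond it. Compound 4, `O=C(Nc1ccccc1F)N[C@H]1CC[C@H](Oc2ccc(F)cc2)CC1`, differs from compound 3 by fluoro in place of chloro on an aromatic carbon. Among the compounds with values here, no measured step exchanges one halogen for another on this ring; the steps that touch this ring, a 1.4-fold lower number from compound 1 to compound 2 (0.14 log units; within the scatter) and a 2.2-fold lower number from compound 1 to compound 3 (0.34 log units; beyond the scatter), replace the whole aryl group and move the number only a little. The step of a 1.3-fold higher number from compound 3 to compound 4 (0.12 log units; within the scatter) is therefore expected to stay within the scatter. Compound 4 is estimated at 12000 nM in this assay, with a range of 6000 nM to 25000 nM.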

Compound 4, half-maximal inhibitory concentration: 17500 nM
Compound 4: middle estimate off by 1.5-fold (0.16 log units), on the low side; the measured number falls inside the stated range.
By their numbers in this assay, from the lowest: compounds 3, 2, 4 and 1 (each within the scatter of the next, the first and the last beyond it).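

Within the data shown here, the step of a 1.9-fold higher number from compound 3 to compound 4 (0.28 log units; within the scatter) is the first exchange of one halogen for another on this ring, on the aromatic carbon ortho to a large group, and it stays within the scatter. The steps of a 1.2-fold higher number from compound 2 to compound 4 (0.08 log units; within the scatter) and a 1.1-fold lower number from compound 1 to compound 4 (0.06 log units; within the scatter) also stay within it, so 2-fluorophenyl cannot be told apart from 3-methylphenyl or 4-fluorophenyl in this assay. Nothing at hand offers an explanation for these small steps. On these data alone, whether an amine or a carboxylic acid on this aromatic carbon would move the number beyond the scatter remains open.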